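The source may report more compounds than this note shows. Statements on the series, on what has been measured and on what is new or still open speak of the compounds shown alone.

Measured compounds, in a functional assay on HOS-TE85 cells (Homo sapiens) for inhibition, read by CCK-8 assay, with a stated time of 72 h; on this read-out lower numbers stand for stronger inhibition and higher numbers for weaker inhibition:
Compound 1 `O=C(NCCCCc1ccccc1)c1cccc(C2SCC(=O)N2c2cnccn2)c1`: > 1000 nM
Compound 2 `COc1ccccc1N1C(=O)CSC1C(=O)NCCCCc1ccccc1`: > 1000 nM

Compound 1 gives no number in this assay, only the limit > 1000 nM. Compound 2 likewise reaches only a limit, > 1000 nM. The series therefore has no measured potency to start from, and the evidence so far is the limit of > 1000 nM in this assay, at which 2 of the 2 values shown sit.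

Compound 3 `COc1cc(F)ccc1N1C(=O)CSC1c1cccc(C(=O)NCCCCc2ccccc2)c1` keeps the rest of compound 1 but carries 4-fluoro-2-methoxyphenyl in place of pyrazin-2-yl on an amide-type nitrogen in a ring. Within the data shown here, no measured step shows what such a change does here, so the expectation is loose. A modest move towards stronger inhibition in this assay is expected, though a result that again reaches only a limit would be no surprise. The estimated step is a step that the limit leaves unreadable from compound 1 to compound 3. For compound 3 the expected value is 1500 nM, with an estimated range of 150 nM to 10000 nM.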

Compound 3, half-maximal inhibitory concentration: 71.1 nM
Estimate against measurement, compound 3: 21-fold (1.32 log units) above; measured number outside the range, below it.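

In this assay, the group on the amide-type nitrogen in a ring proves able to lift the series off its limit: 4-fluoro-2-methoxyphenyl in place of pyrazin-2-yl gives an at least 14-fold lower number from compound 1 to compound 3 (1.14 log units; beyond the scatter). The value of compound 1, > 1000 nM, is a limit and not a number, so this step is a bound and not an exact size. Compound 3 therefore supplies the only measured number among the compounds shown, while the others remain at the limit: the limit of > 1000 nM in this assay, at which 2 of the 3 values shown sit.

The compounds shown do not separate the contribution of the fluoro substituent from that of the methoxy substituent, as both enter in the same change. They also leave open how a 4-chloro-2-methoxyphenyl group, or a carboxylic acid or an amine on this aromatic ring, would fare at this position.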